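The source may hold more compounds than are shown below. What is called first, only, known or untested is meant among the compounds shown, and "the series" means these compounds.

Working notes on the dithiocarbamate series. Compound 1 `Nc1ccccc1NC(=O)c1ccc(CSC(=S)N2CCN(C3CCCCC3)CC2)cc1` gives 16.9% in a functional assay on MGC-803 cells (Homo sapiens) for antiproliferative activity, read by CCK-8 assay, with a stated time of 72 h, tested at 2 uM; on this read-out higher numbers stand for a stronger effect at the one concentration tested and lower numbers for a weaker effect; compound 2 `Nc1ccccc1NC(=O)c1ccc(CSC(=S)N2CCN(c3ccncc3)CC2)cc1` gives 64.8%; compound 3 `Nc1ccccc1NC(=O)c1ccc(CSC(=S)N2CCN(c3cccnc3)CC2)cc1` gives 27.6%. Compound 3 sits second highest of the three numbers: its nearest neighbour is compound 1, with the step of a number 10.7 percentage points higher from compound 1 to compound 3 (beyond the scatter), and its furthest is compound 2, with the step of a number 37.2 percentage points lower from compound 2 to compound 3 (beyond the scatter). Among the measured compounds shown here, the single largest step in the set, a number 47.9 percentage points higher from compound 1 to compound 2 (beyond the scatter), shows how much the group on the ring amine nitrogen can move the read-out.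

Compound 4 `Nc1ccccc1NC(=O)c1ccc(CSC(=S)N2CCN(c3cnccn3)CC2)cc1` is not yet measured. It differs from compound 3 by pyrazin-2-yl in place of pyridin-3-yl on an amine nitrogen in a ring. For the measured compounds named here, no measured step swaps pyridin-3-yl for another six-membered aromatic ring with two hetero atoms, so the only bearing comes from the two aryl steps above, which show the aromatic substituent varying widely. Compound 4 is therefore expected to stay near compound 3, with a step of a number 7.4 percentage points higher from compound 3 to compound 4 (within the scatter) in this assay carrying wide uncertainty. The estimate for compound 4 is 35%, between 15% and 62%.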

Compound 4, a percentage reported as inhibition, at one concentration (the size of the read-out at that concentration, not a potency): 27.1%
Estimate against measurement, compound 4: 7.9 percentage points above; the measured number falls inside the stated range.
By their numbers in this assay, from the lowest: compound 1; then compounds 4 and 3 (each within the scatter of the next); then compound 2.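

The step of a number 0.5 percentage points lower from compound 3 to compound 4 (within the scatter) in this assay means that pyrazin-2-yl and pyridin-3-yl cannot be told apart at this position, even though pyrazin-2-yl carries one more ring nitrogen and one more hydrogen-bond acceptor. Among the compounds shown here, with a number 37.7 percentage points lower from compound 2 to compound 4 (beyond the scatter) on the one side and a number 10.2 percentage points higher from compound 1 to compound 4 (beyond the scatter) on the other, pyrazin-2-yl joins pyridin-3-yl in the middle of the set, clear of cyclohexyl but well short of pyridin-4-yl. For the compounds shown here, compound 2 therefore remains the only compound with a large step over all the others, and it stands against any reading that a nitrogen-containing aromatic ring on this amine nitrogen is enough for the high read-out seen with it.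

As far as these compounds go, whether a plain phenyl or a pyrimidine ring on the same nitrogen would fall with compound 2 or with compound 3 stays open. No measurement shown here explains why pyridin-4-yl stands apart from the other aromatic groups.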